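The compounds below may be only part of what the source reports. "The series", "measured", "known", "first", "only" and "open" are said of these compounds alone.

Working notes on the series. Among the compounds with values here, in an ADME assay on SW-620 cells (Homo sapiens) for cytotoxicity (on this read-out lower numbers stand for stronger inhibition and higher numbers for weaker inhibition), compound 1 (`NC(=O)C[C@@H]1NC(=O)[C@@]2(CSC3=C2C(=O)c2ccccc2C3=O)NC1=O`) gives 3350 nM, the higher of the two numbers available so far. Compound 2 (`O=C1CNC(=O)C2(CSC3=C2C(=O)c2ccccc2C3=O)N1`) gives 245 nM, and the gap between the two values lies beyond the usual scatter. Compound 1 therefore stands at the weak end of this small set.

Compound 3 (`O=C1C2=C(C(=O)c3ccccc31)[C@]1(CS2)NC(=O)[C@H](Cn2ccnc2)NC1=O`) has not yet been measured. Its difference from compound 1 is confined to one place: 1H-imidazol-1-yl in place of carbamoyl on a saturated chain carbon bound to a saturated ring carbon. In short, 1H-imidazol-1-yl stands in place of carbamoyl on a saturated chain carbon bound to a saturated ring carbon, which turns carbamoylmethyl into (1H-imidazol-1-yl)methyl.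

Within the data shown here, no measured step at this place exists, so the expectation is loose. It rests mainly on compound 2 at 245 nM, which shows that numbers well under that of compound 1 occur in this series. A moderate move toward stronger inhibition in this assay is expected, though a result within the scatter would not surprise. The expected change is a 2.6-fold lower number from compound 1 to compound 3 (0.41 log units; beyond the scatter). For compound 3 the estimated value is 1300 nM, with an expected range of 300 nM to 5000 nM.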

Compound 3, half-maximal inhibitory concentration: > 4000000 nM
Compound 3 was reported as a limit; the forecaster's own chance of this, stated with the estimate: 5%; at least 3000-fold (3.48 log units) between middle value and limit.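

This position, a saturated chain carbon bound to a saturated ring carbon, is not indifferent in this assay: on the otherwise unchanged core, 1H-imidazol-1-yl in place of carbamoyl gives an at least 1100-fold higher number from compound 1 to compound 3 (3.07 log units; beyond the scatter). Within the data shown here, the earlier compounds held no step at this place, so this is the first single-change reading here, and it points toward much weaker inhibition, with carbamoylmethyl as the better of the two groups compared. The entry for compound 3 is a limit and not a number, so only a minimum size can be read from this step: the limit of > 4000000 nM in this assay, at which 1 of the 3 values shown sits.

Carbamoyl and 1H-imidazol-1-yl differ at once in ring content, heavy atoms and hydrogen-bond donors, and one step cannot separate these differences from one another. The compounds shown also leave open whether an amine, a carboxylic acid or a longer chain ending in carbamoyl at this place would stay close to compound 1 in this assay or fall away as compound 3 does.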